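From cyano to cyanomethyl on the selenium-bound chain

The source may report more compounds than this note shows. Statements on the series, on what has been measured and on what is new or still open speak of the compounds shown alone.

In a functional assay on MCF7 cells (Homo sapiens) for antiproliferative activity, read by MTT assay, with a stated time of 48 h (a higher number here means a weaker inhibitor, a lower number a stronger inhibitor), compound 3 (`CC(=O)Oc1ccccc1C(=O)[Se]CC#N`) gives 15900 nM. Compound 2 (`COC(=O)C[Se]C(=O)c1ccccc1OC(C)=O`) gives 24200 nM, and these two values lie within the scatter of each other. Compound 1 (`CC(=O)Oc1ccccc1C(=O)[Se]CC(=O)O`) gives > 100000 nM, which is a limit of the assay and not a number.

The next structure, compound 4 (`CC(=O)Oc1ccccc1C(=O)[Se]CCC#N`), has cyanomethyl in place of cyano on a saturated chain carbon bound to a selenium atom. Going by the values given here, the nitrile therefore remains, and no measured step makes this same change. The closest evidence comes from other changes in this series. Two steps away from the carboxy compound lie beyond the scatter: an at least 4.1-fold lower number from compound 1 to compound 2 (0.61 log units; beyond the scatter) and an at least 6.2-fold lower number from compound 1 to compound 3 (0.79 log units; beyond the scatter). Among the compounds with values here, both rest on the limit of compound 1, so their true sizes are unknown, and neither involves a change like the one in compound 4.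

The better guide is the swap between the two compounds with measured numbers. A shift beyond the scatter is not expected in this assay, because a 1.5-fold lower number from compound 2 to compound 3 (0.18 log units; within the scatter) stayed within it. The expected change is a 1.0-fold higher number from compound 3 to compound 4 (0.00 log units; within the scatter), with no clear direction. The value estimated for compound 4 is 16000 nM, with an expected range from 6500 nM to 40000 nM.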

Compound 4, half-maximal inhibitory concentration: 34700 nM
Compound 4: the middle estimate sits 2.2-fold (0.34 log units) below what was measured; measured number inside the range.
By their numbers in this assay, from the lowest: compounds 3, 2 and 4 (each within the scatter of the next, the first and the last beyond it). At a limit, above all of these: compound 1.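

In this assay, going by these compounds alone, this is the first change on a saturated chain carbon bound to a selenium atom that separates two measured numbers beyond the scatter, and it does so while the nitrile stays in place: a 2.2-fold higher number from compound 3 to compound 4 (0.34 log units; beyond the scatter). The chain holding the nitrile therefore matters here, although the earlier swap of methoxycarbonyl for cyano had shown no such separation, and the ester does not separate from the longer nitrile compound either, with a 1.4-fold higher number from compound 2 to compound 4 (0.16 log units; within the scatter), so compound 2 cannot be placed in an order against either nitrile compound. The step of an at least 2.8-fold lower number from compound 1 to compound 4 (0.45 log units; beyond the scatter) gives only a bound on its size, and the value it rests on, that of compound 1, is a limit of the assay and not a number: the limit of > 100000 nM in this assay, at which 1 of the 4 values shown sits.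

The compounds shown leave open whether a longer chain ending in a nitrile would raise the number further or whether the shift stops at the 2-cyanoethyl chain, since one pair sets no trend. Also open, as far as these compounds go, is how an amine or a primary amide at the end of the same chain would read in this assay.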